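This account rests on a few compounds, and the source may have more. Where it says the series, first, only, none or still open, it means among the compounds named here.

Compound 1, `COc1cccc(/C=C2\CCC/C(=C\c3ccc(Cl)c(Cl)c3)C2=O)c1OC`, and compound 2, `COc1cccc(/C=C2\CCC/C(=C\c3cc(Cl)cc(Cl)c3)C2=O)c1OC`, share one core and differ only in the group on the chain. In a functional assay on HT-1080 cells (Homo sapiens) for cytotoxicity, read by MTT assay, with a stated time of 72 h (on this read-out lower numbers stand for stronger inhibition and higher numbers for weaker inhibition), compound 1 gives 10800 nM, and compound 2 gives 6100 nM. The change between them, (3,5-dichlorophenyl in place of 3,4-dichlorophenyl on a double-bonded chain carbon bound to a double-bonded ring carbon), brought a 1.8-fold lower number from compound 1 to compound 2 (0.25 log units; within the scatter).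

Compound 3, `COc1ccc(/C=C2\CCC/C(=C\c3ccc(Cl)c(Cl)c3)C2=O)cc1OC`, carries a core that differs from the core of compound 1; that difference is not broken down here. In this assay compound 3 gives 3100 nM, which puts it at the low end of the three numbers, separated from compound 1 by a gap beyond the scatter but from compound 2 only by one within it.

Compound 4, `COc1ccc(/C=C2\CCC/C(=C\c3cc(Cl)cc(Cl)c3)C2=O)cc1OC`, is not yet measured. It stands to compound 3 as compound 2 stands to compound 1, the same change: 3,5-dichlorophenyl in place of 3,4-dichlorophenyl on a double-bonded chain carbon bound to a double-bonded ring carbon. Because compound 1 to compound 2 gave a 1.8-fold lower number from compound 1 to compound 2 (0.25 log units; within the scatter), a step of similar size is expected here, a 1.6-fold lower number from compound 3 to compound 4 (0.19 log units; within the scatter), though a single earlier instance within the scatter is a thin basis. Compound 4 is therefore estimated at 2000 nM, with a likely range from 900 nM to 4500 nM.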

Compound 4, half-maximal inhibitory concentration: 3000 nM
The estimate for compound 4 lay 1.5-fold (0.18 log units) below the measured number, within the range that was stated.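

In this assay the move to 3,5-dichlorophenyl in place of 3,4-dichlorophenyl gave a 1.0-fold lower number from compound 3 to compound 4 (0.01 log units; within the scatter) on the core of compound 3. Set beside the earlier instance, the steps on the two cores cannot be told apart: the same change on two cores in this assay, a 1.8-fold lower number (0.25 log units; within the scatter) from compound 1 to compound 2 and a 1.0-fold lower number (0.01 log units; within the scatter) from compound 3 to compound 4, 1.7-fold (0.23 log units) apart, within the scatter of two such steps. Among these compounds, this fits the change carrying over between these two cores, but since neither step rises above the scatter, it shows only that the change made no clear difference on either core, not that both share a real step of one size, and it says nothing about any further core.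

The compounds shown leave open whether a swap on the same phenyl ring would give a step beyond the scatter if the chlorines gave way to other groups, such as fluorine, trifluoromethyl, a nitrile or an amine. They also leave open whether the two dichlorophenyl groups would stay this close on a core carrying something other than the two methoxy groups, such as a carboxylic acid.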